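Swapping 3-methoxyphenyl for 4-cyanophenyl on an amide nitrogen

The source may report more compounds than this note shows. Statements on the series, on what has been measured and on what is new or still open speak of the compounds shown alone.

Compound 1 `CCc1ccc(NC(=O)C2CCN(C/C=C/c3ccccc3)CC2)cc1` gives 23300 nM
Compound 2 `COc1cccc(NC(=O)C2CCN(C/C=C/c3ccccc3)CC2)c1` gives 78600 nM
Compound 3 `O=C(Nc1cccc(C(F)(F)F)c1)C1CCN(C/C=C/c2ccccc2)CC1` gives 11400 nM

These three values come from a functional assay on HepG2 cells (Homo sapiens) for inhibition, read by MTT assay, with a stated time of 72 h (on this read-out higher numbers stand for weaker inhibition and lower numbers for stronger inhibition), and compound 2 has the highest number of the three, which makes it the weakest inhibitor of this small set. The next candidate is compound 4 `N#Cc1ccc(NC(=O)C2CCN(C/C=C/c3ccccc3)CC2)cc1` and it has not yet been measured. Its difference from compound 2 is 4-cyanophenyl in place of 3-methoxyphenyl on an amide-type nitrogen and the rest of the structure stays the same. In words, 4-cyanophenyl sits in place of 3-methoxyphenyl on an amide-type nitrogen.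

Among the measured compounds shown here, two measured steps bear on this change. One is a 3.4-fold higher number from compound 1 to compound 2 (0.53 log units; beyond the scatter) and it links 3-methoxyphenyl with 4-ethylphenyl. The other is a 6.9-fold lower number from compound 2 to compound 3 (0.84 log units; beyond the scatter) and it replaces methoxy with trifluoromethyl. Both are modest, and in both the compound carrying 3-methoxyphenyl has the higher number. None of the three measured compounds carries a nitrile, so this is indirect evidence from very few compounds. A modest fall in the number is therefore a reasonable expectation in this assay but not a certain one. The expected step is a 3.1-fold lower number from compound 2 to compound 4 (0.50 log units; beyond the scatter) and the range around it stays wide. Compound 4 is estimated at 25000 nM (expected range from 8000 nM to 75000 nM).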

Compound 4, half-maximal inhibitory concentration: 38300 nM
The estimate for compound 4 lay 1.5-fold (0.19 log units) below the measured number; the measured number falls inside the stated range.
By their numbers in this assay, from the lowest: compound 3; then compounds 1 and 4 (each within the scatter of the next); then compound 2.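

In this assay, the 4-cyanophenyl group on the amide-type nitrogen gives a 2.1-fold lower number from compound 2 to compound 4 (0.31 log units; beyond the scatter), so all three other groups measured at this place now give lower numbers than 3-methoxyphenyl does, and none among these four compounds goes against that. Putting cyano in place of ethyl on an aromatic carbon gives a 1.6-fold higher number from compound 1 to compound 4 (0.22 log units; within the scatter), which means that these two groups cannot be told apart on this read-out, even though the nitrile brings a triple bond that ethyl does not have. Nothing among the data shown explains why the number moves with these changes.

The compounds shown change the group and its place on the ring together, so it stays open whether the lower number of compound 4 relative to compound 2 follows the nitrile, its place on the ring, or the removal of methoxy, and 3-cyanophenyl and 4-methoxyphenyl would help separate these. Going by these compounds, it is also open how an amine, a carboxylic acid or a longer chain on this ring would fare in this assay.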